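Working notes: methyl substitution from compound 1 to compound 4

The source may hold more compounds than are shown below. What is called first, only, known or untested is meant among the compounds shown, and "the series" means these compounds.

Measured so far:
compound 1 `O=C(N/N=C\c1ccccc1)Nc1nnc(COc2ccc3ccccc3c2)o1`: 300 mg/kg
compound 2 `C/C(=N/NC(=O)Nc1nnc(COc2ccc3ccccc3c2)o1)c1ccc(N)cc1`: 300 mg/kg
compound 3 `O=C(NN=C(c1ccccc1)c1ccccc1)Nc1nnc(COc2ccc3ccccc3c2)o1`: 300 mg/kg

In a functional assay on the whole organism (strain Swiss albino) with Mus musculus as the target, in the maximal electroshock model, with a stated time of 4 h (a higher number here means that more compound is needed for the effect, a lower number that less compound is needed), compound 1 gives 300 mg/kg. Compound 2 gives 300 mg/kg and compound 3 gives 300 mg/kg, so compound 1 stands level with both within the scatter. Among the compounds with values here, the one measured step, no change at the digits printed from compound 1 to compound 2 (within the scatter), exchanged the group on the amide-type nitrogen and left the read-out unchanged.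

Compound 4 `Cc1ccc(/C=N\NC(=O)Nc2nnc(COc3ccc4ccccc4c3)o2)cc1` differs from compound 1 by methyl in place of hydrogen on an aromatic carbon. Within the data shown here, no measured step touches this ring position, so the step from compound 1 to compound 2 is only an indirect guide; it shows the series tolerating a larger exchange without movement. The expected step is therefore none beyond the scatter, no change at the digits printed from compound 1 to compound 4 (within the scatter). For compound 4 the estimate is 300 mg/kg, ranging from 150 mg/kg to 600 mg/kg.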

Compound 4, minimum effective dose: 300 mg/kg
For compound 4 middle estimate and measured number coincide at the digits printed; measured number inside the range.
By their numbers in this assay, from the lowest: compounds 1, 2, 3 and 4 (each within the scatter of the next).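

In this assay, within the data shown here, the change from phenyl to 4-methylphenyl gives the first reading at this ring position (no change at the digits printed from compound 1 to compound 4 (within the scatter)), so methyl in place of hydrogen on an aromatic carbon, para to a large group, leaves the read-out level. The group exchange on the amide-type nitrogen reads the same (no change at the digits printed from compound 2 to compound 4 (within the scatter)), and all four compounds stay level. No evidence at hand explains this flat response.

Going by these compounds, whether a carboxylic acid or a longer chain such as butyl at this position would separate from compound 1 remains open. A chloro group there is equally undecided.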